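The compounds below may be only part of what the source reports. "The series", "measured", "known", "first", "only" and "open" are said of these compounds alone.

In a functional assay on CEM-SS cells (Homo sapiens) for cytotoxicity (a higher number here means a weaker inhibitor, a lower number a stronger inhibitor), compound 2 `Clc1cc2nc(Cl)n(Cc3ccccc3Cl)c2cc1Cl` gives 70000 nM. Compound 3 `COc1ccc(Cn2c(Br)nc3cc(Cl)c(Cl)cc32)cc1` gives 60000 nM, and compound 1 `Nc1nc2cc(Cl)c(Cl)cc2n1Cc1ccccc1Cl` gives 36000 nM. Compound 2 cannot be separated from either of the other two on these numbers, as all of its gaps lie within the scatter.

The next comparison is compound 4 `Clc1cc2nc(Br)n(Cc3ccccc3Cl)c2cc1Cl`, where the change from compound 2 is bromo in place of chloro on an aromatic carbon. This puts bromo in place of chloro on an aromatic carbon, between two ring nitrogen atoms, and leaves the rest of the structure untouched.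

For the measured compounds named here, only one measured step concerns this same carbon: a 1.9-fold higher number from compound 1 to compound 2 (0.29 log units; within the scatter). That swap of amino for chloro is a different change, yet it still does not leave the scatter. Compound 3, at 60000 nM, already carries bromo at this place, but it also differs elsewhere, so it offers only indirect support. Going by the values given here, no measured pair isolates chloro against bromo.

On this evidence, no shift beyond the scatter is expected in this assay. The estimated change is a 1.1-fold lower number from compound 2 to compound 4 (0.03 log units; within the scatter), which is a step of no meaningful size. For compound 4 the expected value is 65000 nM, with an estimated range from 35000 nM to 120000 nM.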

Compound 4, half-maximal inhibitory concentration: 74000 nM
Estimate against measurement, compound 4: 1.1-fold (0.06 log units) below, and the stated range covers the measured number.
By their numbers in this assay, from the lowest: compounds 1, 3, 2 and 4 (each within the scatter of the next, the first and the last beyond it).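

In this assay, the exchange of chloro for bromo on this aromatic carbon, between two ring nitrogen atoms, now has a matched pair, and it gives a 1.1-fold higher number from compound 2 to compound 4 (0.02 log units; within the scatter), so the two halogens cannot be told apart here. For the compounds shown here, the comparison of amino with bromo at the same carbon gives a 2.1-fold higher number from compound 1 to compound 4 (0.31 log units; beyond the scatter), the only step at this place that passes the scatter, and only modestly, whereas a 1.9-fold higher number from compound 1 to compound 2 (0.29 log units; within the scatter) stays inside it, so the amino compound separates from the bromo compound but not from the chloro compound. No measured data bear on why these steps have the sizes they do.

All the compounds shown carry amino, chloro or bromo on this carbon, so it remains open whether a carboxylic acid, an iodo group or a longer chain there would move the number clearly outside this narrow band. Also open, going by these compounds, is whether the small gap between amino and bromo would hold on repeat measurement, or would appear at all with another group on the ring nitrogen of the shared core.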